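Cytotoxicity Limits in a Benzofuranyl Pyrazoline Series

This account rests on a few compounds, and the source may have more. Where it says the series, first, only, none or still open, it means among the compounds named here.

Measured so far:
compound 1 `O=C(c1ccncc1)N1N=C(c2cc3ccccc3o2)CC1c1ccccc1[N+](=O)[O-]` — > 245000 nM
compound 2 `COc1ccc(C2CC(c3cc4ccccc4o3)=NN2C(=O)c2ccncc2)cc1` — > 200000 nM
compound 3 `CCn1cc(C(=O)N2N=C(c3cc4ccccc4o3)CC2c2ccccc2[N+](=O)[O-])c(=O)c2ccc(C)nc21` — > 85400 nM

All three values in an ADME assay on Vero cells (Chlorocebus sabaeus) for cytotoxicity, read by MTT assay, with a stated time of 72 h (a lower number here means a stronger inhibitor, a higher number a weaker inhibitor), are limits of the assay rather than numbers. Compound 1 reaches only the limit > 245000 nM. Compound 2 likewise reaches only the limit > 200000 nM. Compound 3 too reaches only the limit > 85400 nM.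

The change from compound 1 to compound 2 is 4-methoxyphenyl in place of 2-nitrophenyl on a saturated ring carbon. Its size is a step that the two limits leave unreadable from compound 1 to compound 2, as the two limits in this assay (the limit of > 245000 nM in this assay, at which 1 of the 3 values shown sits, (the limit of > 200000 nM in this assay, at which 1 of the 3 values shown sits)) leave nothing readable.

Compound 4 `CCn1cc(C(=O)N2N=C(c3cc4ccccc4o3)CC2c2ccc(OC)cc2)c(=O)c2ccc(C)nc21` is not yet measured. The change from compound 3 to compound 4 is 4-methoxyphenyl in place of 2-nitrophenyl on a saturated ring carbon, the same kind of change as before; around the place, the ring atom next to the exchanged group bears a large group in compound 3 rather than the (pyridin-4-yl)carbonyl group of compound 1. How the core of compound 3 differs from that of compound 1 is not broken down here.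

For compound 4 in this assay a step that the limit leaves unreadable from compound 3 to compound 4 is expected, resting on compound 3 giving only the limit of > 85400 nM in this assay, at which 1 of the 3 values shown sits, and on compound 1 and compound 2 both sitting at limits. Compound 4 is estimated at 200000 nM, most likely again reported as a limit, with a range of 80000 nM to 500000 nM.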

Compound 4, half-maximal inhibitory concentration: > 156000 nM
Compound 4 was reported as a limit (the forecaster's own chance of this, stated with the estimate: 85%); the middle value does not contradict the limit.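

Compound 3 and compound 4 are both reported only as limits in this assay, so no step can be read between them. The compounds shown leave open whether any of them has a measurable value in this assay, and whether 4-methoxyphenyl in place of 2-nitrophenyl shifts that value on either core.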